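Compound 4: A Pyridin-2-yl Ether Judged From Three Neighbours

The compounds below may be only part of what the source reports. "The series", "measured", "known", "first", "only" and "open" are said of these compounds alone.

Of the compounds shown here, three have been measured in a functional assay on Jurkat cells (Homo sapiens) for inhibition; a lower number here means a stronger inhibitor, a higher number a weaker inhibitor. Within the data shown here, compound 2 `COC(=O)c1cc(OCC(=O)[C@H](CC(=O)O)NC(=O)[C@@H](NC(=O)COc2cccc3ccccc23)C(C)C)no1` gives 71000 nM and is the only one to yield a number. Compound 1 `CC(C)c1cc(OCC(=O)[C@H](CC(=O)O)NC(=O)[C@@H](NC(=O)COc2cccc3ccccc23)C(C)C)no1` reaches only > 200000 nM in this assay, which is a limit of the assay rather than a number. Compound 3 `CC(C)[C@H](NC(=O)COc1cccc2ccccc12)C(=O)N[C@@H](CC(=O)O)C(=O)COn1nnc2ccccc21` likewise returns only the limit > 200000 nM. Among the measured compounds shown here, compound 2 therefore holds the single measured value, while the other two sit at a limit (the limit of > 200000 nM in this assay, at which 2 of the 3 values shown sit).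

Compound 4 `CC(C)[C@H](NC(=O)COc1cccc2ccccc12)C(=O)N[C@@H](CC(=O)O)C(=O)COc1ccccn1` is not yet measured. It differs from compound 2 in one place: pyridin-2-yl in place of 5-(methoxycarbonyl)-1,2-oxazol-3-yl on an oxygen on a saturated carbon.

For the measured compounds named here, two measured steps bear on this change. The step of an at least 2.8-fold lower number from compound 1 to compound 2 (0.44 log units; beyond the scatter) shows that the ring carrying methoxycarbonyl is read more strongly than the ring carrying isopropyl. The step of an at least 2.8-fold higher number from compound 2 to compound 3 (0.44 log units; beyond the scatter) shows that replacing the whole ring with another group loses the number altogether. Compound 4 also removes the 5-(methoxycarbonyl)-1,2-oxazol-3-yl group, putting pyridin-2-yl in its place. Both precedents point the same way, so a higher number is expected for compound 4, about a 2.8-fold higher number from compound 2 to compound 4 (0.45 log units; beyond the scatter). Compound 4 is accordingly estimated at 200000 nM, within a range from 60000 nM to 600000 nM, and this assay may well report only a limit for it.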

Compound 4, half-maximal inhibitory concentration: > 200000 nM
Compound 4 was reported as a limit; the forecaster's own chance of this, stated with the estimate: 55%; the middle value lies on the limit itself.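

In this assay compound 4 gives > 200000 nM, which is a limit of the assay and not a number. The step of an at least 2.8-fold higher number from compound 2 to compound 4 (0.44 log units; beyond the scatter) adds a second full replacement of the 5-(methoxycarbonyl)-1,2-oxazol-3-yl group on this oxygen on a saturated carbon, here by the smaller pyridin-2-yl, and again no number results, so among the four compounds only the group carrying methoxycarbonyl gives one. The steps from compound 1 to compound 4 and from compound 3 to compound 4 cannot be read, as both ends of each sit at the same limit: the limit of > 200000 nM in this assay, at which 3 of the 4 values shown sit.

On these data alone, how compound 1, compound 3 and compound 4 rank among themselves remains open, as does how far each lies from compound 2. The compounds shown also cannot separate the part played by the methoxycarbonyl group from that of the 1,2-oxazol-3-yl ring carrying it, a question that a pyridin-2-yl bearing methoxycarbonyl, or a 1,2-oxazol-3-yl bearing a carboxylic acid or a primary amide instead, would address.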